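This account rests on a few compounds, and the source may have more. Where it says the series, first, only, none or still open, it means among the compounds named here.

Measured compounds:
compound 1 `COc1ccc(C2OC(c3cc(OC)c(OC)c(OC)c3)=NN2C(C)=O)cc1` — 57000 nM
compound 2 `COc1cccc(C2OC(c3cc(OC)c(OC)c(OC)c3)=NN2C(C)=O)c1` — 45000 nM
compound 3 `COc1ccc(C2=NN(C(C)=O)C(c3ccc(OC)cc3)O2)cc1` — a limit, > 100000 nM

In a functional assay on L1210 cells (Mus musculus) for antiproliferative activity, read by MTT assay, with a stated time of 72 h (on this read-out lower numbers stand for stronger inhibition and higher numbers for weaker inhibition), compound 1 gives 57000 nM and compound 2 gives 45000 nM; the change 3-methoxyphenyl in place of 4-methoxyphenyl on a saturated ring carbon gives a 1.3-fold lower number from compound 1 to compound 2 (0.10 log units; within the scatter). The value of compound 3 in this assay is a limit, > 100000 nM, one of the values at the limit of > 100000 nM in this assay, at which 1 of the 3 values shown sits. The difference between the core of compound 3 and the core of compound 1 is not broken down here.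

Compound 4 `COc1ccc(C2=NN(C(C)=O)C(c3cccc(OC)c3)O2)cc1` is not yet measured. It carries the change (3-methoxyphenyl in place of 4-methoxyphenyl on a saturated ring carbon), the same kind of change as from compound 1 to compound 2, though in compound 4 the place lies two ring bonds from the ring atom that bears a 4-methoxyphenyl group rather than a large group. Since compound 1 to compound 2 gave a 1.3-fold lower number from compound 1 to compound 2 (0.10 log units; within the scatter), a small step is expected: a step that the limit leaves unreadable from compound 3 to compound 4. Compound 4 is estimated at 120000 nM in this assay, with a range from 50000 nM to 300000 nM, and a limit rather than a number is likely.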

Compound 4, half-maximal inhibitory concentration: 41000 nM
Beside the measured number, compound 4's estimate is 2.9-fold (0.47 log units) above it; measured number outside the range, below it.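

In this assay, 3-methoxyphenyl in place of 4-methoxyphenyl on a saturated ring carbon gives an at least 2.4-fold lower number from compound 3 to compound 4 (0.38 log units; beyond the scatter), a step beyond the scatter on the core of compound 3. Whether the change carries over between the two cores at one size, or its size depends on the core, is not settled: the same change on two cores in this assay, a 1.3-fold lower number (0.10 log units; within the scatter) from compound 1 to compound 2 and an at least 2.4-fold lower number (0.38 log units; beyond the scatter) from compound 3 to compound 4; the limit leaves it open whether they differ. The value of compound 3 is a limit, > 100000 nM.

The compounds shown leave open how this assay responds at this place to a phenyl ring bearing an amine or a carboxylic acid instead of the methoxy group. They also leave open whether a longer acyl chain in place of the acetyl group alters the step.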